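Adding a second chloro group to compound 2

The source may hold more compounds than are shown below. What is called first, only, known or untested is meant among the compounds shown, and "the series" means these compounds.

In a functional assay on A549 cells (Homo sapiens) for antiproliferative activity, read by MTT assay, with a stated time of 72 h (a lower number here means a stronger inhibitor, a higher number a weaker inhibitor), compound 2 `NC1=NC2(CCOCC2)N(OCCCOc2ccc(Cl)cc2)C(N)=N1` gives 360 nM and holds the higher of the two exact numbers in this series. Its nearest neighbour, compound 1 `CC(C)(C)c1ccc(OCCCON2C(N)=NC(N)=NC23CCSCC3)cc1` at 1 nM lies on the stronger side, a gap well beyond the scatter. Compound 3 `NC1=NC2(CCSCC2)N(OCCCOc2cc(Cl)c(Cl)cc2Cl)C(N)=N1` returns no number, only the assay limit > 100000 nM for this compound.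

The step to compound 4 `NC1=NC2(CCOCC2)N(OCCCOc2ccc(Cl)cc2Cl)C(N)=N1` keeps the core of compound 2 and places chloro in place of hydrogen on an aromatic carbon, ortho to a large group and meta to a chloro group. This turns 4-chlorophenyl into 2,4-dichlorophenyl.

Going by the values given here, no measured pair isolates this change, so the expectation starts from compound 2 at 360 nM and stays close to it. In this assay no step beyond the scatter is expected, though the uncertainty is wide. The estimated change is a 1.7-fold higher number from compound 2 to compound 4 (0.22 log units; within the scatter) as a small drift toward weaker inhibition. For compound 4 the expected value is 600 nM with an estimated range of 60 nM to 6000 nM overall.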

Compound 4, half-maximal inhibitory concentration: 70 nM
Compound 4: the middle estimate sits 8.6-fold (0.93 log units) above what was measured, and the stated range covers the measured number.
By their numbers in this assay, from the lowest: compound 1; then compound 4; then compound 2. At a limit, above all of these: compound 3.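

Chloro in place of hydrogen on an aromatic carbon, ortho to a large group and meta to a chloro group, gives in this assay a 5.1-fold lower number from compound 2 to compound 4 (0.71 log units; beyond the scatter). Going by these compounds alone, this is the first one-place step, and it shows that with the core held fixed, 2,4-dichlorophenyl gives a lower number than 4-chlorophenyl, so this position accepts a chloro group without loss in this read-out. Nothing at hand bears on the reason for this step.

Compound 3 stands at > 100000 nM, which is a limit, and it differs from compound 4 in more than one place, so it cannot be read as a further step on this ring. As far as these compounds go, whether a fluoro, methyl or methoxy group at this same position gives a step of similar size remains open.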